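Compound 2 and the 3-chloro-4-fluorophenyl change

The source may report more compounds than this note shows. Statements on the series, on what has been measured and on what is new or still open speak of the compounds shown alone.

In an in vitro ADME assay on microsomes from liver (Rattus norvegicus) for metabolic stability (a lower number here means slower removal, a higher number faster removal of the compound), compound 1 (`CC(C)NC(=O)[C@H]1CC[C@@H](n2/c(=N/C(=O)c3ccc(C#N)c(F)c3)[nH]c3ccc(CN4CCC(C(C)(C)O)CC4)cc32)CC1`) gives 29 mL.min-1.g-1 as a measured number. Compound 2 (`CC(C)NC(=O)[C@H]1CC[C@@H](n2/c(=N/C(=O)c3ccncc3)[nH]c3ccc(CN4CCC(C(C)(C)O)CC4)cc32)CC1`) stands at < 14 mL.min-1.g-1 in the same assay, and this is a limit, not a number (the limit of < 14 mL.min-1.g-1 in this assay, at which 1 of the 2 values shown sits). Among the compounds with values here, one measured step bears on what follows: an at least 2.0-fold lower number from compound 1 to compound 2 (0.31 log units; beyond the scatter) (beyond the scatter), with pyridin-4-yl in place of 4-cyano-3-fluorophenyl on a carbonyl carbon.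

Compound 3 (`CC(C)NC(=O)[C@H]1CC[C@@H](n2/c(=N/C(=O)c3ccc(F)c(Cl)c3)[nH]c3ccc(CN4CCC(C(C)(C)O)CC4)cc32)CC1`) differs from compound 2 at that same place, with 3-chloro-4-fluorophenyl in place of pyridin-4-yl on a carbonyl carbon. The change again puts an aromatic ring of carbon only on the carbonyl, as in compound 1 at 29 mL.min-1.g-1 in this assay, so that value is the best available guide. The two phenyl groups are not the same, which leaves the estimate wide. A move of similar size to the measured step is expected, in the opposite direction, toward a higher number and faster removal. The expected change is an at least 2.1-fold higher number from compound 2 to compound 3 (0.33 log units; beyond the scatter) on this estimate. For compound 3 the estimated value is 30 mL.min-1.g-1 (expected range 15 mL.min-1.g-1 to 60 mL.min-1.g-1).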

Compound 3, intrinsic clearance in microsomes: 44 mL.min-1.g-1
Beside the measured number, compound 3's estimate is 1.5-fold (0.17 log units) below it; the measured number falls inside the stated range.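

Placing a ring of carbon only back on the carbonyl reverses the earlier step, giving an at least 3.1-fold higher number from compound 2 to compound 3 (0.49 log units; beyond the scatter) in this assay, so the pyridin-4-yl group is now set against two different phenyl groups at this position rather than one. Those two phenyl groups cannot be told apart in this assay, with a 1.5-fold higher number from compound 1 to compound 3 (0.18 log units; within the scatter), and so, among these three compounds, the one carrying pyridin-4-yl stands apart, and none goes against this pattern. The value for compound 2 remains a limit, not a number, so the steps to and from it have a known minimum but no known full size: the limit of < 14 mL.min-1.g-1 in this assay, at which 1 of the 3 values shown sits.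

The compounds shown leave open how far compound 2 really lies from compound 1 and compound 3, and whether the separation seen here is tied to pyridin-4-yl alone or extends to other rings that contain nitrogen. They also leave open how this assay would respond to a pyrimidinyl group on this carbonyl, or to a phenyl ring carrying an amine or a carboxylic acid.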